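Swapping fluoro for methyl at a clearance limit

This account rests on a few compounds, and the source may have more. Where it says the series, first, only, none or still open, it means among the compounds named here.

Compound 1 `Cc1ccc(N2CC[C@@H](NC(=O)Nc3ccccc3Br)C2)cc1F`: <= 11 mL.min-1.g-1, a limit
Compound 2 `O=C(Nc1ccccc1Br)N[C@@H]1CCN(c2cccc(F)c2)C1`: <= 11 mL.min-1.g-1, a limit

Both entries come from an in vitro ADME assay on microsomes from liver (Rattus norvegicus) for metabolic stability; on this read-out lower numbers stand for slow clearance and higher numbers for fast clearance. Compound 2 stands at <= 11 mL.min-1.g-1, which is a limit and not a number. Among the compounds with values here, the same holds for the whole series so far: the limit of <= 11 mL.min-1.g-1 in this assay, at which 2 of the 2 values shown sit. Compound 3 `Cc1cccc(N2CC[C@@H](NC(=O)Nc3ccccc3Br)C2)c1` differs from compound 2 by one change, methyl in place of fluoro on an aromatic carbon. Within the data shown here, the only measured step that bears on this is a step that the two limits leave unreadable from compound 1 to compound 2, where hydrogen takes the place of methyl on an aromatic carbon. Compound 1 carries such a methyl and gives <= 11 mL.min-1.g-1, again a limit. No clear step is therefore expected in this assay, and the estimated step is a step that the limit leaves unreadable from compound 2 to compound 3. For compound 3 the expected value is 10 mL.min-1.g-1, with an estimated range of 6 mL.min-1.g-1 to 22 mL.min-1.g-1.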

Compound 3, intrinsic clearance in microsomes: <= 11 mL.min-1.g-1
Compound 3: a limit, no number; the forecaster's own chance of this, stated with the estimate: 70%; the middle value is on the limit's open side.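

No step among compound 1, compound 2 and compound 3 can be read in this assay, because each result is a limit and not a number: the limit of <= 11 mL.min-1.g-1 in this assay, at which 3 of the 3 values shown sit.

How the true clearance values of these compounds compare, including any difference between methyl and fluoro, stays open.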